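The compounds below may be only part of what the source reports. "The series", "measured", "known", "first", "only" and "open" are said of these compounds alone.

Measured so far in an assay on cells for inhibition of histone deacetylase 8 (Homo sapiens), read by fluorescence, with a stated time of 30 min; on this read-out lower numbers stand for stronger inhibition and higher numbers for weaker inhibition:

Compound 1 `O=C1NC(=O)/C(=C\c2ccc(OCC(=O)N3N=C(c4ccccc4)CC3c3ccc(F)cc3F)cc2)S1` gives 34000 nM in this assay.
Compound 2 `Cc1ccc(C2CC(c3ccccc3)=NN2C(=O)COc2ccc(/C=C3/SC(=O)NC3=O)cc2)cc1` gives 31000 nM in this assay.
Compound 3 `O=C1NC(=O)/C(=C\c2ccc(OCC(=O)N3N=C(c4ccc(F)cc4)CC3c3ccc(F)cc3F)cc2)S1` reaches only the limit of this assay, > 50000 nM, and no number is known for it.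

Compound 1 and compound 2 differ in one place, (4-methylphenyl in place of 2,4-difluorophenyl on a saturated ring carbon). The step is a 1.1-fold lower number from compound 1 to compound 2 (0.04 log units; within the scatter), so the two values cannot be told apart.

The cores of compound 1 and compound 3 differ by fluoro in place of hydrogen on an aromatic carbon. This step is an at least 1.4-fold higher number from compound 1 to compound 3 (0.16 log units; that floor lies within the scatter); the higher value here is the limit of this assay, marked by the limit of > 50000 nM in this assay, at which 1 of the 3 values shown sits, and the floor of the step lies within the scatter.

Compound 4 `Cc1ccc(C2CC(c3ccc(F)cc3)=NN2C(=O)COc2ccc(/C=C3/SC(=O)NC3=O)cc2)cc1`, not yet measured, differs from compound 3 by 4-methylphenyl in place of 2,4-difluorophenyl on a saturated ring carbon. The surroundings of the place are not the same as in the earlier pair: there the ring atom two ring bonds away bears a phenyl group, here a 4-fluorophenyl group, so the change is of the same kind rather than the same.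

For compound 4 the step from compound 3 is expected to be a step that the limit leaves unreadable from compound 3 to compound 4, resting on the step of a 1.1-fold lower number from compound 1 to compound 2 (0.04 log units; within the scatter), which lies within the scatter. Compound 4 is estimated at 55000 nM in this assay, with a range from 25000 nM to 120000 nM, and a limit rather than a number is likely.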

Compound 4, half-maximal inhibitory concentration: > 50000 nM
Compound 4 was reported as a limit; the forecaster's own chance of this, stated with the estimate: 60%; the middle value is on the limit's open side.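

In this assay compound 4 gives > 50000 nM, which is a limit and not a number. Fluoro in place of hydrogen on an aromatic carbon now has a second reading, an at least 1.6-fold higher number from compound 2 to compound 4 (0.20 log units; that floor lies within the scatter), while the step between compound 3 and compound 4 cannot be read, with a limit at both ends. Neither floor lies beyond the scatter, so the change may carry from one core to the other, but neither a real shift on either core nor a match in size between the two cores is shown: the same change on two cores in this assay, an at least 1.4-fold higher number (0.16 log units; that floor lies within the scatter) from compound 1 to compound 3 and an at least 1.6-fold higher number (0.20 log units; that floor lies within the scatter) from compound 2 to compound 4; the limit leaves it open whether they differ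

Going by these compounds, the true size of the fluoro change stays open, with compound 3 and compound 4 both ending at a limit: the limit of > 50000 nM in this assay, at which 2 of the 4 values shown sit. Also open is whether a methoxy group or a carboxylic acid on that aromatic carbon, or an amine on the 4-methylphenyl ring, would give readable numbers in this assay.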